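A chloro to methoxy swap on compound 2

This account rests on a few compounds, and the source may have more. Where it says the series, first, only, none or still open, it means among the compounds named here.

Compound 1 `COc1ccc(-c2nc3cc(C(C)=O)ccc3n2C2CCCCC2)cc1` and compound 2 `C/C(=N\NC(N)=O)c1ccc2c(c1)nc(-c1ccc(Cl)cc1)n2C1CCCCC1` have both been tested in an ADME assay on MDBK cells (Bos taurus) for cytotoxicity, read by MTT assay, with a stated time of 96 h; a higher number here means that more compound is tolerated, a lower number that less compound is tolerated. In this assay compound 1 gives > 100000 nM, which is a limit of the assay and not a number. Compound 2 gives > 100000 nM, which is also a limit. Compound 2 therefore stands at the limit of > 100000 nM in this assay, at which 2 of the 2 values shown sit, and no exact value is known for it.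

Compound 3 `COc1ccc(-c2nc3cc(/C(C)=N/NC(N)=O)ccc3n2C2CCCCC2)cc1` differs from compound 2 in one place: methoxy in place of chloro on an aromatic carbon. It has methoxy in place of chloro on an aromatic carbon, para to a large group, so 4-chlorophenyl becomes 4-methoxyphenyl. Compound 1 carries the same 4-methoxyphenyl group, and its reading of > 100000 nM is a limit too, which is the main ground for the expectation here. The expected step of a number no higher from compound 2 to compound 3 (the limit leaves the size open) in this assay is none beyond the scatter, in either direction, and a further limit is the likeliest report. For compound 3 the estimated value is 100000 nM, with an expected range of 40000 nM to 150000 nM.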

Compound 3, half-maximal cytotoxic concentration: 54000 nM
For compound 3 the middle estimate is 1.9-fold (0.27 log units) above the measured one; low and high end bracket the measured number.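

In this assay compound 3 gives 54000 nM, the only exact number among the compounds shown, so the 4-methoxyphenyl group can be carried by a compound that gives an exact number. The change from 4-chlorophenyl to 4-methoxyphenyl, para to a large group, gives an at least 1.8-fold lower number from compound 2 to compound 3 (0.26 log units; that floor lies within the scatter), which does not establish a step beyond the scatter, though it leaves room for a larger one. With the 4-methoxyphenyl group held constant, the group of 7 heavy atoms in place of the group of 3 heavy atoms on an aromatic carbon gives an at least 1.8-fold lower number from compound 1 to compound 3 (0.26 log units; that floor lies within the scatter), and this too is only a floor, so neither step has a known size: the limit of > 100000 nM in this assay, at which 2 of the 3 values shown sit.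

No pair among the compounds shown has two exact numbers, so the full size of either change remains unknown. From the compounds shown here alone, it also remains open how fluoro, hydroxyl or an amine on the same aromatic carbon would read, and whether any of these would give an exact number rather than a limit.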